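The source may hold more compounds than are shown below. What is called first, only, known or untested is meant among the compounds shown, and "the series" means these compounds.

Compound 1 `COc1cc2c(cc1OC)CN(S(=O)(=O)c1ccc(-n3cc(COc4ccc5ccccc5c4)nn3)cc1)CC2` is one of two compounds with a number in a functional assay on HepG2 cells (Homo sapiens) for cytotoxicity, read by MTT assay, with a stated time of 48 h; a lower number here means a stronger inhibitor, a higher number a weaker inhibitor. In this assay compound 1 gives 1260 nM, which is the lower of the two numbers. The other measured compound, compound 2 `O=S(=O)(c1ccc(-n2cc(COc3ccccc3)nn2)cc1)N1CCc2ccccc2C1`, differs from compound 1 in more than one place, and in this assay compound 2 gives 6500 nM, a weaker result that lies beyond the usual scatter.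

The unmeasured compound 3 `COc1cc2c(cc1OC)CN(S(=O)(=O)c1ccc(-n3cc(COc4ccccc4C)nn3)cc1)CC2` keeps the core of compound 1 and changes one place: 2-methylphenyl in place of naphthalen-2-yl on an oxygen on a saturated carbon. Going by the values given here, no single-change step between measured compounds is known here, so the expectation for this move rests only on what compound 1 and compound 2 show. The step from compound 1 to compound 3 is expected to be modest, a 2.0-fold higher number from compound 1 to compound 3 (0.30 log units; within the scatter), toward a weaker inhibitor. For compound 3 the estimate in this assay is 2500 nM, within a range from 1000 nM to 7000 nM.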

Compound 3, half-maximal inhibitory concentration: 1480 nM
Compound 3: middle estimate off by 1.7-fold (0.23 log units), on the high side; the range from low to high includes it.
By their numbers in this assay, from the lowest: compounds 1 and 3 (each within the scatter of the next); then compound 2.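

In this assay, putting 2-methylphenyl in place of naphthalen-2-yl on the oxygen gives a 1.2-fold higher number from compound 1 to compound 3 (0.07 log units; within the scatter), so on the core of compound 1 these two groups cannot be told apart, although the group goes from two aromatic rings to one and from 10 heavy atoms to 7. Compound 1 and compound 2 differ in more than one place and could not speak for this group alone, whereas this pair isolates it. No available finding explains why the two groups read alike.

Going by these compounds, what the methyl group of 2-methylphenyl contributes remains open, as this single pair cannot separate it from the rest of the group. Also open, on these data alone, is how this assay would read with an amine, a carboxylic acid or a longer chain on the oxygen in place of these aromatic groups.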